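The source may report more compounds than this note shows. Statements on the series, on what has been measured and on what is new or still open speak of the compounds shown alone.

Measured in an ADME assay on HEK293 cells (Homo sapiens) for cytotoxicity, read by CellTiter-Glo, with a stated time of 72 h; on this read-out lower numbers stand for an effect already at smaller amounts and higher numbers for an effect only at larger amounts of compound:
- Compound 1 `CC1=C2CC(C)(C)/C=C/C/C(C)=C\C3=C[C@H](C)C[C@]3(O2)C1=O`: 26000 nM
- Compound 2 `CC(=O)O[C@H]1/C=C/C(C)(C)CC2=C(C)C(=O)[C@]3(C[C@@H](C)C=C3/C=C\1C)O2`: 26000 nM

On these numbers, compound 2 stands level with compound 1. Within the data shown here, the only measured step, no change at the digits printed from compound 1 to compound 2 (within the scatter), puts acetoxy in place of hydrogen on a saturated ring carbon. The next structure is compound 3 `CC1=C2CC(C)(C)/C=C/[C@H](OC(=S)n3ccnc3)/C(C)=C\C3=C[C@H](C)C[C@]3(O2)C1=O`, and the change is a group of 7 heavy atoms (4 carbon, 2 nitrogen, 1 sulfur; one five-membered aromatic ring with 2 hetero atoms) in place of a group of 3 heavy atoms (2 carbon, 1 oxygen; no ring), on an oxygen on a saturated carbon. That single step offers limited guidance for such a different group, so only a modest shift toward lower numbers is expected, a 1.4-fold lower number from compound 2 to compound 3 (0.16 log units; within the scatter). Compound 3 is expected at about 18000 nM, with an estimated range of 6000 nM to 40000 nM.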

Compound 3, half-maximal effective concentration: 26000 nM
The estimate for compound 3 lay 1.4-fold (0.16 log units) below the measured number; measured number inside the range.
By their numbers in this assay, from the lowest: compounds 1, 2 and 3 (each within the scatter of the next).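

The read-out in this assay shows no change at the digits printed from compound 2 to compound 3 (within the scatter) when the acetyl on the oxygen gives way to a larger group carrying a five-membered aromatic ring. Against the plain hydrogen on the saturated ring carbon, the same group gives no change at the digits printed from compound 1 to compound 3 (within the scatter) even though it brings a ring and sulfur, so this position has now held two very different groups with no readable shift. Nothing available explains this flat result. Still open, as far as these compounds go, is whether an amine, a carboxylic acid or a longer chain here would move the number, and whether a change elsewhere on the shared core would.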